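A few compounds are considered here, and "the series" means these few. Any claim that something is new, unique, unknown or untested is made for them only; others in the source may bear on it.

Measured compounds in this set:
- compound 1, `COc1ccc(NC(=O)[C@H]2CCCN2C(=O)C2(c3cccc(Cl)c3)CCCC2)cc1`: 100 nM
- compound 2, `O=C(Nc1cnc2[nH]ncc2c1)[C@H]1CCCN1C(=O)C1(c2cccc(Cl)c2)CCCC1`: 15.9 nM

Both were run in an assay on isolated protein for inhibition of histone acetyltransferase p300 (Homo sapiens), with a stated time of 60 min; on this read-out higher numbers stand for weaker inhibition and lower numbers for stronger inhibition. Compound 2 gives the lowest number of the two, and the step from compound 1 to it, a 6.3-fold lower number from compound 1 to compound 2 (0.80 log units; beyond the scatter), lies beyond the scatter.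

Compound 3, `CNC(=O)c1cccc(NC(=O)[C@H]2CCCN2C(=O)C2(c3cccc(Cl)c3)CCCC2)c1`, is not yet measured. It differs from compound 2 in one place: a group of 10 heavy atoms (8 carbon, 1 nitrogen, 1 oxygen; one six-membered aromatic ring of carbon only) in place of a group of 9 heavy atoms (6 carbon, 3 nitrogen; one five-membered aromatic ring with 2 hetero atoms, one six-membered aromatic ring with 1 hetero atom), on an amide-type nitrogen. Going by the values given here, the only measured step that bears on this position is the one from compound 1 to compound 2, which exchanged one six-membered aromatic ring of carbon only for the fused bicyclic group and lowered the number. From the compounds shown here alone, compound 3 moves back to a six-membered aromatic ring of carbon only, now carrying a methylcarbamoyl group instead of methoxy, so the step is expected to run the other way, toward the region of compound 1, though the new substituent is untested here and leaves the size open. The estimated step is a 3.8-fold higher number from compound 2 to compound 3 (0.58 log units; beyond the scatter). Compound 3 is estimated at 60 nM, with a range from 20 nM to 200 nM.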

Compound 3, half-maximal inhibitory concentration: 1260 nM
Estimate against measurement, compound 3: 21-fold (1.32 log units) below; the whole stated range lies below it.
By their numbers in this assay, from the lowest: compound 2; then compound 1; then compound 3.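

In this assay, the aromatic group on the amide-type nitrogen proves far more sensitive than the earlier pair suggested: replacing the group of compound 2 with 3-(methylcarbamoyl)phenyl gives (a 79-fold higher number from compound 2 to compound 3 (1.90 log units; beyond the scatter)), a much larger change than the earlier (a 6.3-fold lower number from compound 1 to compound 2 (0.80 log units; beyond the scatter)). A six-membered aromatic ring of carbon only therefore does not fix the number near that of compound 1, since the change from 4-methoxyphenyl to 3-(methylcarbamoyl)phenyl gives (a 13-fold higher number from compound 1 to compound 3 (1.10 log units; beyond the scatter)), showing that what the ring carries and where it carries it matter at this position. No measurement at hand offers an explanation for this loss.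

The comparison of compound 1 with compound 3 changes both the substituent and its place on the ring, so the compounds shown cannot separate these two contributions. Also open, from the compounds shown here alone, is how a plain phenyl, or a phenyl carrying a carboxylic acid or a primary amine in place of the methylcarbamoyl group, would compare with compound 1 and compound 3 on this read-out.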